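The source may report more compounds than this note shows. Statements on the series, on what has been measured and on what is new or still open speak of the compounds shown alone.

In a functional assay on DU-145 cells (Homo sapiens) for cytotoxicity, read by MTT assay (on this read-out lower numbers stand for stronger inhibition and higher numbers for weaker inhibition), three compounds built on a shared core have been measured. They carry different groups on the aromatic ring. Compound 1 (`COC(=O)C[C@H]1C[C@H](O)[C@@H](C)[C@@H](c2ccc(C)cc2)N1`) gives 330000 nM, compound 2 (`COC(=O)C[C@H]1C[C@H](O)[C@@H](C)[C@@H](c2ccc(C(C)C)cc2)N1`) gives 27400 nM, and compound 3 (`COC(=O)C[C@H]1C[C@@H](O)[C@@H](C)[C@@H](c2ccc(F)cc2)N1`) gives 51700 nM. The values of compound 2 and compound 3 lie within the usual scatter of each other, so they cannot be ranked, while compound 1 shows a clearly higher number than compound 3.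

The next compound, compound 4 (`COC(=O)C[C@H]1C[C@H](O)[C@@H](C)[C@@H](c2ccc(F)cc2)N1`), keeps every atom and bond of compound 3: the two compounds have the same atoms and bonds and differ only in configuration as drawn: 1 of 4 stereo elements differ; a stereocentre at a saturated ring carbon is drawn R in compound 3 and S in compound 4. In other words, a stereocentre at a saturated ring carbon is drawn R in compound 3 and S in compound 4.

For the measured compounds named here, no measured step changes configuration alone, so nothing here fixes the direction of this change. Going by the values given here, the only measured step, a 12-fold lower number from compound 1 to compound 2 (1.08 log units; beyond the scatter), swaps one group for another, so it bears on this change only indirectly. It does show that a single change in this series can move this assay a long way, which argues for a wide range.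

The expected result, a 1.4-fold higher number from compound 3 to compound 4 (0.13 log units; within the scatter), is therefore no shift beyond the scatter, though this is a cautious estimate. For compound 4, the estimated value is 70000 nM, with an expected range from 18000 nM to 270000 nM.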

Compound 4, half-maximal inhibitory concentration: "not active" (no number reported)
The entry for compound 4 holds no number, so the estimate cannot be set against anything.
By their numbers in this assay, from the lowest: compounds 2 and 3 (each within the scatter of the next); then compound 1.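

For the compounds shown here, compound 4 is reported only as "not active", with no number, while compound 3 gives 51700 nM, so no step between compound 3 and compound 4 can be read. The comparison would have rested on one structural fact: the fact that compounds 3 and 4 differ only in the configuration as drawn

From the compounds shown here alone, whether and how far that drawn configuration shifts the result in this assay stays open.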